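The source may hold more compounds than are shown below. What is called first, only, known or untested is meant among the compounds shown, and "the series" means these compounds.

Measured in a functional assay on Huh-7 cells (Homo sapiens) for antiproliferative activity, read by CCK-8 assay, with a stated time of 72 h; on this read-out lower numbers stand for stronger inhibition of growth and higher numbers for weaker inhibition of growth:

- Compound 1 `CCCNS(=O)(=O)c1ccc(Nc2ncc3c(n2)N(c2ccn(C)n2)C(CC)C(=O)N3C)cc1`: 8880 nM
- Compound 2 `CCCCNS(=O)(=O)c1ccc(Nc2ncc3c(n2)N(C2CCCC2)[C@H](CC)C(=O)N3C)cc1`: 225 nM
- Compound 3 `CCC1C(=O)N(C)c2cnc(-n3ccc4cc(F)ccc43)nc2N1c1ccn(C)n1`: "not active" (no number reported)

Compound 3 has no number on this read-out. It is reported only as "not active" (no number reported), so it cannot be placed exactly against the two measured compounds, compound 1 at 8880 nM and compound 2 at 225 nM.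

Compound 4 `CCC1C(=O)N(C)c2cnc(-n3ccc4cc(C(N)=O)ccc43)nc2N1c1ccn(C)n1` has not yet been measured. It carries carbamoyl in place of fluoro on an aromatic carbon.

Among the compounds with values here, with no measured step to draw on, any expectation in this assay is loose. A move toward stronger inhibition of growth is expected, but only a modest one and of uncertain size, since compound 3 offers no number to start from. The closest measured reference is compound 1 at 8880 nM, which shares more of its structure with compound 4 than compound 2 does. There remains a real chance that no number is reported at all.

Compound 4 is estimated at 6000 nM, with an expected range of 1000 nM to 30000 nM.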

Compound 4, concentration for 50% growth inhibition: "not active" (no number reported)
The entry for compound 4 holds no number, so the estimate cannot be set against anything.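

Within the data shown here, compound 3 and compound 4 are both reported only as "not active", with no number, so no step between them can be read. No evidence bears on this result. The compounds shown leave open whether carbamoyl in place of fluoro changes growth inhibition at all.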